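Swapping the vinylpyridine for an ethynylpyridine on the alkyne

The source may report more compounds than this note shows. Statements on the series, on what has been measured and on what is new or still open speak of the compounds shown alone.

Compound 2 `C=Cc1ccnc(C#Cc2ccc3ncn(-c4ccnc(N)n4)c3c2)c1` gives the lowest of the two numbers available in an assay on Sf9 cells for inhibition of mitogen-activated protein kinase kinase kinase 14 variant S549D (Homo sapiens), with a stated time of 30 min, in the presence of a further agent that is not named here (a higher number here means a weaker inhibitor, a lower number a stronger inhibitor), at 1580 nM. Among the measured compounds shown here, its only measured neighbour, compound 1 `C=Cc1cc(C#Cc2ccc3ncn(-c4ccnc(N)n4)c3c2)ccn1`, gives 20000 nM in this assay, and the step from its ring to that of compound 2 was a 13-fold lower number from compound 1 to compound 2 (1.10 log units; beyond the scatter). Compound 3 `C#Cc1cccc(C#Cc2ccc3ncn(-c4ccnc(N)n4)c3c2)n1` differs from compound 2 by a group of 8 heavy atoms (7 carbon, 1 nitrogen; one six-membered aromatic ring with 1 hetero atom) in place of a group of 8 heavy atoms (7 carbon, 1 nitrogen; one six-membered aromatic ring with 1 hetero atom), on a triple-bonded carbon. For the measured compounds named here, the single measured step concerned the position of the ring nitrogen, whereas the change to compound 3 keeps the nitrogen placement of compound 2 and alters the substituent on that ring and where it sits; it therefore bears only loosely on this step. A modest shift is expected, if any, and the estimated step from compound 2 to compound 3 is a 1.6-fold higher number from compound 2 to compound 3 (0.20 log units; within the scatter). Compound 3 is expected to give about 2500 nM in this assay, within 800 nM to 8000 nM.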

Compound 3, half-maximal inhibitory concentration: 3160 nM
Compound 3: middle estimate off by 1.3-fold (0.10 log units), on the low side, and the stated range covers the measured number.
By their numbers in this assay, from the lowest: compounds 2 and 3 (each within the scatter of the next); then compound 1.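

At this triple-bonded carbon, a ring group with a triple bond outside the aromatic ring takes the place of one with a double bond, and the result in this assay is a 2.0-fold higher number from compound 2 to compound 3 (0.30 log units; within the scatter), so the two groups cannot be told apart here. Compound 1 now stands apart from two neighbours rather than one, with a 6.3-fold lower number from compound 1 to compound 3 (0.80 log units; beyond the scatter) adding to the earlier step, which shows that a low number at this position is not confined to the group in compound 2. No measurement available here explains these differences.

The compounds shown leave open how much of the step from compound 1 to compound 3 comes from the double or triple bond and how much from the arrangement of the ring. They also leave open whether an amine or a longer chain on this ring would keep the number in the same range.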